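A methoxy group gives way to hydrogen

The source may report more compounds than this note shows. Statements on the series, on what has been measured and on what is new or still open speak of the compounds shown alone.

Three related compounds have been tested in an ADME assay on HEK-293T cells (Homo sapiens) for cytotoxicity, read by CCK-8 assay, with a stated time of 24 h; a lower number here means that less compound is tolerated, a higher number that more compound is tolerated. Compound 1 (`CN(Cc1ccccc1)C(=O)CSc1c[nH]c2c(Br)cccc12`) gives 52500 nM. Compound 3 (`COc1ccccc1CNC(=O)CSc1c[nH]c2cccc(Br)c12`) gives > 100000 nM, which is a limit and not a number. Compound 2 (`COc1ccccc1CNC(=O)CSc1cn(C)c2ccccc12`) gives > 100000 nM, again a limit and not a number, so it stands at the limit of > 100000 nM in this assay, at which 2 of the 3 values shown sit.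

Compound 4 (`Cn1cc(SCC(=O)NCc2ccccc2)c2ccccc21`) has not been measured yet. It carries hydrogen in place of methoxy on an aromatic carbon, so that 2-methoxyphenyl becomes phenyl (hydrogen in place of methoxy on an aromatic carbon). No measured pair among these compounds shows this change on its own, so any forecast here is tentative. The expected step of a number no higher from compound 2 to compound 4 (the limit leaves the size open) stays within the usual scatter, with no direction favoured. A reading that again reports only a limit is the likeliest outcome. In this assay the estimate for compound 4 is 100000 nM, with an expected range from 40000 nM to 250000 nM.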

Compound 4, half-maximal cytotoxic concentration: 95500 nM
Compound 4: middle estimate off by 1.0-fold (0.02 log units), on the high side, and the stated range covers the measured number.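

In this assay, replacing 2-methoxyphenyl with phenyl gives an at least 1.0-fold lower number from compound 2 to compound 4 (0.01 log units; that floor lies within the scatter). Among the compounds shown here, this is the first direct view of this change on an aromatic carbon, and compound 4 gives a real number where compound 2 gives only a limit. The full size of the step stays unknown because the starting value is a limit of the assay and not a number: the limit of > 100000 nM in this assay, at which 2 of the 4 values shown sit.

Going by these compounds, whether another group at this position, such as a chlorine atom or an amine, would shift the tolerated concentration beyond the usual scatter remains open. The compounds shown also hold no pair that tests the same change on a bromine-bearing core, so it is unclear whether this result would carry over to such compounds.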